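Swapping the Aryl Group on the Hydrazone of Compound 2

A few compounds are considered here, and "the series" means these few. Any claim that something is new, unique, unknown or untested is made for them only; others in the source may bear on it.

Compound 2 `O=C(N/N=C/c1ccc(Cl)cc1)c1cccnc1Nc1cccc(C(F)(F)F)c1` holds the highest of the three numbers in a functional assay on the whole organism (strain Wistar) for inhibition, with Rattus norvegicus as the target, read by paw edema, with a stated time of 1 h, at a dose of 10 mg/kg by the intraperitoneal route (a higher number here means more inhibition at the dose given (going by the name of the read-out), a lower number less inhibition), giving 67.2%. Compound 3 `O=C(N/N=C/c1cccc(O)c1)c1cccnc1Nc1cccc(C(F)(F)F)c1` comes nearest with 63.8%, so that a number 3.4 percentage points lower from compound 2 to compound 3 (within the scatter). Compound 1 `O=C(N/N=C/c1ccc(F)cc1)c1cccnc1Nc1cccc(C(F)(F)F)c1` gives 43.2%, and a number 24 percentage points higher from compound 1 to compound 2 (beyond the scatter). Compound 4 `COc1ccc(/C=N/NC(=O)c2cccnc2Nc2cccc(C(F)(F)F)c2)cc1OC` is not yet measured; it differs from compound 2 by 3,4-dimethoxyphenyl in place of 4-chlorophenyl on a carbon with a double bond to nitrogen. Among the measured compounds shown here, the steps that bear on this change sit at the same place: a number 20.6 percentage points higher from compound 1 to compound 3 (beyond the scatter), whereas a number 3.4 percentage points lower from compound 2 to compound 3 (within the scatter); a change of this group can thus move the read-out by a modest amount or not at all. Compound 4 is therefore expected to show a number 9.2 percentage points lower from compound 2 to compound 4 (within the scatter), likely within the scatter. Compound 4 is estimated at 58%, with a range from 40% to 75%.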

Compound 4, a percentage reported as inhibition, in the whole organism at one dose (the size of the read-out at that dose, not a potency): 70%
Compound 4: the middle estimate sits 12 percentage points below what was measured, and the stated range covers the measured number.
By their numbers in this assay, from the lowest: compound 1; then compounds 3, 2 and 4 (each within the scatter of the next).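

In this assay there is a number 2.8 percentage points higher from compound 2 to compound 4 (within the scatter) and a number 6.2 percentage points higher from compound 3 to compound 4 (within the scatter) so 3,4-dimethoxyphenyl on the carbon with a double bond to nitrogen stands level with 4-chlorophenyl and 3-hydroxyphenyl, although it has more heavy atoms than 4-chlorophenyl and hydrogen-bond acceptors that group lacks. Only 4-fluorophenyl stands apart, with a number 26.8 percentage points higher from compound 1 to compound 4 (beyond the scatter) as the widest step at this place. Nothing measured here explains why these groups read alike. Still open, on these data alone, is whether an aryl group carrying an amine or a carboxylic acid would hold this level, and whether a single methoxy group would do the same.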